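A few compounds are considered here, and "the series" means these few. Any claim that something is new, unique, unknown or untested is made for them only; others in the source may bear on it.

Measured so far:
- compound 1, `CCCCCOc1ccc(C(=O)N(C(=S)OCCN2C(=O)c3ccccc3C2=O)c2ccc(F)cc2)cc1`, > 100000 nM
- compound 2, `Cc1ccccc1C(=O)N(C(=S)OCCN1C(=O)c2ccccc2C1=O)c1ccc(Cl)cc1`, 21000 nM
- compound 3, `O=C1c2ccccc2C(=O)N1CCOC(=S)N(C(=O)c1ccc(Cl)c([N+](=O)[O-])c1)c1ccccc1`, 51000 nM

All three compounds were tested in an ADME assay on MT4 cells (Homo sapiens) for cytotoxicity, read by MTT assay; a higher number here means that more compound is tolerated, a lower number that less compound is tolerated. Compound 1 reaches only the limit of the measurement, (the limit of > 100000 nM in this assay, at which 1 of the 3 values shown sits), so no number is known for it. Of the two numbers that are known, compound 2 holds the lower one, and the gap up to compound 3 lies beyond the scatter, so compound 2 is the less well tolerated of those two.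

The next compound, compound 4, `O=C1c2ccccc2C(=O)N1CCOC(=S)N(C(=O)c1ccc(F)c(F)c1)c1ccc(Cl)cc1`, keeps the shared core of compound 2 and alters only the group on a carbonyl carbon whose other neighbours are an amide-type nitrogen: 3,4-difluorophenyl in place of 2-methylphenyl on a carbonyl carbon.

Among the compounds with values here, no measured pair differing in just this one place exists here, so the size of the step can only be guessed from the three values shown. Both numbers known sit within a narrow band, and compound 1 sits at the limit. For compound 4 the expected step is a 1.7-fold higher number from compound 2 to compound 4 (0.22 log units; within the scatter), a small move that could well stay within the scatter. Compound 4 is therefore estimated at 35000 nM, with a range from 12000 nM to 100000 nM.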

Compound 4, half-maximal cytotoxic concentration: 52000 nM
For compound 4 the middle estimate is 1.5-fold (0.17 log units) below the measured one; the range from low to high includes it.
By their numbers in this assay, from the lowest: compound 2; then compounds 3 and 4 (each within the scatter of the next). At a limit, above all of these: compound 1.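

In this assay putting 3,4-difluorophenyl in place of 2-methylphenyl on a carbonyl carbon gives a 2.5-fold higher number from compound 2 to compound 4 (0.39 log units; beyond the scatter) with the rest of the molecule unchanged. Within the data shown here, the earlier compounds differed from one another in more than one place, so this is the first reading of what a change at this position alone can do, and the step is modest. Nothing measured here explains the step.

On these data alone, it remains open whether the step comes from losing the methyl, gaining the two fluorines, or both; an unsubstituted phenyl in this place would help to separate these. Also open, as far as these compounds go, is how cells would tolerate a non-aromatic group on this carbonyl, such as a longer alkyl chain or a chain ending in an amine.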